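Chain homologation of two hydroxamic acid series

The source may report more compounds than this note shows. Statements on the series, on what has been measured and on what is new or still open speak of the compounds shown alone.

Compound 1 `Nc1ncnc2c1c(-c1cnc3[nH]ccc3c1)nn2CCCCCCCCC(=O)NO` gives 2270 nM in a functional assay on CNE-2 cells (Homo sapiens) for inhibition, read by MTT assay, with a stated time of 72 h; a lower number here means a stronger inhibitor, a higher number a weaker inhibitor. Compound 2 `Nc1ncnc2c1c(-c1cnc3[nH]ccc3c1)nn2CCCCCCCCCC(=O)NO` gives 2200 nM in this assay, so the change (hydroxycarbamoyl)methyl in place of hydroxycarbamoyl on a saturated chain carbon, eight bonds along the chain from an aromatic nitrogen made a step of a 1.0-fold lower number from compound 1 to compound 2 (0.01 log units; within the scatter). Compound 3 `Nc1nc2cc(-c3nn(CCCCC(=O)NO)c4ncnc(N)c34)ccc2o1` carries a different core; the difference between the two cores is not broken down here. In this assay compound 3 reaches only the limit > 50000 nM, which is a limit and not a number. Compound 4 `Nc1nc2cc(-c3nn(CCCCCC(=O)NO)c4ncnc(N)c34)ccc2o1` differs from compound 3 by (hydroxycarbamoyl)methyl in place of hydroxycarbamoyl on a saturated chain carbon, four bonds along the chain from an aromatic nitrogen; this is the same kind of change as that from compound 1 to compound 2, but here the place lies four bonds along the chain from an aromatic nitrogen rather than eight. Given the flat step a 1.0-fold lower number from compound 1 to compound 2 (0.01 log units; within the scatter) and the limit (the limit of > 50000 nM in this assay, at which 1 of the 3 values shown sits), compound 4 is expected to remain near the limit, an estimated step that the limit leaves unreadable from compound 3 to compound 4. Compound 4 is estimated at 60000 nM, between 15000 nM and 250000 nM.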

Compound 4, half-maximal inhibitory concentration: 37600 nM
Compound 4: the middle estimate sits 1.6-fold (0.20 log units) above what was measured, and the stated range covers the measured number.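

In this assay compound 3 gives > 50000 nM, which is a limit and not a number. The change from hydroxycarbamoyl to (hydroxycarbamoyl)methyl on this core can therefore be stated only as a floor, an at least 1.3-fold lower number from compound 3 to compound 4 (0.12 log units; that floor lies within the scatter), and its true size cannot be read. The compounds shown neither establish nor exclude that the change carries over unaltered from one core to the other: the same change on two cores in this assay, a 1.0-fold lower number (0.01 log units; within the scatter) from compound 1 to compound 2 and an at least 1.3-fold lower number (0.12 log units; that floor lies within the scatter) from compound 3 to compound 4; the limit leaves it open whether they differ

Still open, from the compounds shown here alone, is how a chain longer than that of compound 4 would read on its core, and how a chain shorter than that of compound 1 would read on the core of compound 1. Also open, going by these compounds, is how a carboxylic acid in place of the hydroxycarbamoyl end would read on either core.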